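A few compounds are considered here, and "the series" means these few. Any claim that something is new, unique, unknown or untested is made for them only; others in the source may bear on it.

Measured in a functional assay on RAW264.7 cells (Mus musculus) for inhibition, read by Griess assay, with stated times of 2 h and 24 h; a higher number here means a weaker inhibitor, a lower number a stronger inhibitor:
compound 1, `COc1ccc([C@@H]2CC(=O)c3c(O)cc(OCc4cn(Cc5ccc(C(F)(F)F)cc5)nn4)cc3O2)cc1O`, gives 17700 nM
compound 2, `COc1ccc([C@@H]2C/C(=N\O)c3c(O)cc(OCc4cn(Cc5ccccc5C)nn4)cc3O2)cc1O`, gives 18000 nM
compound 3, `COc1ccc([C@@H]2CC(=O)c3c(O)cc(OCc4cn(Cc5ccccc5C)nn4)cc3O2)cc1O`, gives 13100 nM

Compound 2 stands at the top of these three numbers, yet its distance to compound 1 and to compound 3 is within the scatter, so the three cannot be told apart. Compound 4, `COc1ccc([C@@H]2C/C(=N\O)c3c(O)cc(OCc4cn(Cc5ccccc5Cl)nn4)cc3O2)cc1O`, differs from compound 2 by chloro in place of methyl on an aromatic carbon. Among the measured compounds shown here, the one measured step that bears on a change of the substituent on the benzyl group is a 1.4-fold lower number from compound 1 to compound 3 (0.13 log units; within the scatter), which stayed within the scatter. Compound 4 is therefore expected to stay close to compound 2, with an estimated step of a 1.1-fold lower number from compound 2 to compound 4 (0.02 log units; within the scatter) in this assay, not beyond the scatter. The estimate for compound 4 is 17000 nM, expected between 8000 nM and 36000 nM.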

Compound 4, half-maximal inhibitory concentration: 13400 nM
For compound 4 the middle estimate is 1.3-fold (0.10 log units) above the measured one, within the range that was stated.
By their numbers in this assay, from the lowest: compounds 3, 4, 1 and 2 (each within the scatter of the next).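

In this assay, the swap from 2-methylbenzyl to 2-chlorobenzyl gives a 1.3-fold lower number from compound 2 to compound 4 (0.13 log units; within the scatter). Unlike the earlier step between 4-(trifluoromethyl)phenyl and 2-methylphenyl, this one keeps the place on the ring fixed and changes only the substituent there, and chloro and methyl cannot be told apart at that place. No available evidence accounts for this result. The compounds shown carry only methyl, chloro and trifluoromethyl on this ring, so it stays open whether an amine, a carboxylic acid or a longer chain there would give a step beyond the scatter.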